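Bromo for Ethynyl on the Imidazole Core of Compound 1

The compounds below may be only part of what the source reports. "The series", "measured", "known", "first", "only" and "open" are said of these compounds alone.

Measured compounds:
- compound 1, `C#Cc1nc2ccccc2n1C`: 19400 nM in a functional assay on HCT-116 cells (Homo sapiens) for cytotoxicity, with a stated time of 3 days; on this read-out lower numbers stand for stronger inhibition and higher numbers for weaker inhibition
- compound 2, `C#Cc1nc(C(=O)OCC)cs1`: for compound 2 the read-out is a limit, > 40000 nM
- compound 3, `C#Cc1sc(-c2ccc(F)cc2)nc1C(=O)OCC`: for compound 3 the read-out is also a limit, > 40000 nM

Going by the values given here, compound 1 stands as the only compound of the three with a number in this assay. The other two values are limits, not numbers, and sit at the limit of > 40000 nM in this assay, at which 2 of the 3 values shown sit. No two measured compounds differ in a single place, so no measured step is available, and no cause for the spread can be given from these data.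

The unmeasured compound 4, `Cn1c(Br)nc2ccccc21`, keeps the shared core of compound 1 and the methyl group on it; the change is bromo in place of ethynyl on an aromatic carbon.

Among the compounds with values here, with no measured step to lean on, the expectation is that the step of a 1.3-fold higher number from compound 1 to compound 4 (0.11 log units; within the scatter) is modest, either within the usual scatter or a shift toward weaker inhibition. Given that compound 1 already gives 19400 nM, compound 4 is estimated to land near 25000 nM, with a range from 8000 nM to 60000 nM. There is also a real chance that the assay returns no number at all for compound 4.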

Compound 4, half-maximal inhibitory concentration: > 40000 nM
Compound 4 was reported as a limit; the forecaster's own chance of this, stated with the estimate: 40%; middle value at least 1.6-fold (0.20 log units) away from the limit.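

In this assay compound 4 returns only a limit, > 40000 nM, and not a number. This gives the series its first measured step at this position, on the aromatic carbon between two ring nitrogen atoms: bromo in place of ethynyl gives an at least 2.0-fold higher number from compound 1 to compound 4 (0.31 log units; beyond the scatter), so on this core the ethynyl cannot be exchanged for bromo with the number kept, and the size of the step is bounded on one side only. Compound 1 remains the only compound shown with a number, and the other three values give no measured scale for comparison: the limit of > 40000 nM in this assay, at which 3 of the 4 values shown sit.

Still open, from the compounds shown here alone, is whether another group on this carbon, such as a nitrile, an amine or a longer alkyne chain, would return a number in this assay, or whether ethynyl alone does so among such replacements. Also open are how far compound 4 lies past its limit and what the methyl group contributes, as no compound shown changes that group while keeping the rest of the core of compound 1.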